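The compounds below may be only part of what the source reports. "The series", "measured", "known", "first", "only" and "open" are said of these compounds alone.

In a functional assay on MDA-MB-231 cells (Homo sapiens) for antiproliferative activity, read by MTT assay (a higher number here means a weaker inhibitor, a lower number a stronger inhibitor), compound 1 `CC/C=C\C/C=C\C/C=C\CCCCCCCc1cc(=O)c2c(O)c(C)c(O)cc2o1` gives 6790 nM, a measured number for a compound with a free hydroxy on the shared core. Compound 2 `CCCCC/C=C\C/C=C\CCCCCCCc1cc(=O)c2c(O)c(C)c(OCOC)cc2o1` gives only a limit of the assay, > 87000 nM, and not a number. Compound 3 `CCCCC/C=C\C/C=C\CCCCCCCc1cc(=O)c2c(O)c(C)c(O)cc2o1` has the same chain as compound 2 and differs from it in one place: hydrogen in place of methoxymethyl on an oxygen on an aromatic ring. In words, hydrogen stands in place of methoxymethyl on an oxygen on an aromatic ring, turning methoxymethoxy to hydroxy. Going by the values given here, no measured pair shows this change alone, so the closest guide is compound 1, which also has that hydroxy but a different chain, at 6790 nM. A large move towards stronger inhibition is therefore expected, and the estimated step is an at least 9.6-fold lower number from compound 2 to compound 3 (0.98 log units; beyond the scatter). For compound 3, the expected value is 9000 nM, with an estimated range of 3500 nM to 25000 nM.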

Compound 3, half-maximal inhibitory concentration: 16100 nM
The estimate for compound 3 lay 1.8-fold (0.25 log units) below the measured number, within the range that was stated.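

Replacing methoxymethyl with hydrogen on this oxygen on an aromatic ring, which leaves a free hydroxy, now has a direct reading in this assay: it gives an at least 5.4-fold lower number from compound 2 to compound 3 (0.73 log units; beyond the scatter). This size is only a floor, because compound 2 has a limit of the assay and not a number: the limit of > 87000 nM in this assay, at which 1 of the 3 values shown sits.

With the free hydroxy kept, the chain also matters, though the step is modest: butyl in place of but-1-en-1-yl gives a 2.4-fold higher number from compound 1 to compound 3 (0.37 log units; beyond the scatter).

As far as these compounds go, only hydrogen and methoxymethyl appear on this oxygen, so it remains open how a smaller methyl group or an acetyl group there would read. It also remains open how a fully saturated chain or a longer chain would compare with the two chains shown.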